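The compounds below may be only part of what the source reports. "The series", "measured", "known", "first", "only" and "open" are said of these compounds alone.

Of the compounds shown here, two built on a shared core have so far been tested in a functional assay on U-87MG ATCC cells for antiproliferative activity against U-87 MG (Homo sapiens), read by MTT assay, with a stated time of 48 h, tested at 100 uM; a lower number here means a stronger effect, a higher number a weaker effect of the compound at the concentration tested. Compound 1 `Cc1nc(-c2ccc(Cl)cc2)sc1C(=O)CSc1nc(-c2ccc(Cl)c(Cl)c2)c(C#N)c(=O)[nH]1` gives 36.5%. Compound 2 `COc1ccc(-c2nc(SCC(=O)c3sc(-c4ccc(Cl)cc4)nc3C)[nH]c(=O)c2C#N)cc1` gives 16.6% in this assay, and so compound 2 stands lowest of the two numbers. Among the measured compounds shown here, the single measured step, a number 19.9 percentage points lower from compound 1 to compound 2 (beyond the scatter), came from a change on the six-membered aromatic ring of carbon only, the ring on which compound 2 carries the 4-methoxyphenyl.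

Compound 3 `COc1ccc(-c2nc(SCC(=O)c3sc(-c4ccc(Cl)cc4)nc3C)[nH]c(=O)c2C#N)cc1OC` has not yet been measured. It differs from compound 2 in one place: methoxy in place of hydrogen on an aromatic carbon. The measured step of a number 19.9 percentage points lower from compound 1 to compound 2 (beyond the scatter) exchanged the whole group on that ring, whereas the change to compound 3 only adds a second methoxy to a ring that already carries one, a smaller alteration than the measured one. For the measured compounds named here, no measured step shows how such an added methoxy acts in this assay, so a step within the scatter of repeated measurements is the plainest expectation, though with wide uncertainty. The expected step is a number 1.4 percentage points higher from compound 2 to compound 3 (within the scatter). Compound 3 is therefore estimated at 18% in this assay, within a range from 8% to 32%.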

Compound 3, a percentage reported as activity, at one concentration (the size of the read-out at that concentration, not a potency): 18.7%
Compound 3: middle estimate off by 0.7 percentage points, on the low side, within the range that was stated.
By their numbers in this assay, from the lowest: compounds 2 and 3 (each within the scatter of the next); then compound 1.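

In this assay, the added methoxy, which turns 4-methoxyphenyl into 3,4-dimethoxyphenyl, gives a number 2.1 percentage points higher from compound 2 to compound 3 (within the scatter) and so leaves the two compounds indistinguishable; an aromatic carbon ortho to a methoxy group can carry this second methoxy with no measurable consequence at the one concentration tested. The pair with both ring places filled, 3,4-dichlorophenyl and 3,4-dimethoxyphenyl, shows a number 17.8 percentage points lower from compound 1 to compound 3 (beyond the scatter) and thus separates clearly, so the lower number seen with a methoxy-bearing ring now holds for two compounds rather than one. Nothing measured here explains why either step has the size it has.

Whether a hydroxy group, an amine or a longer chain such as ethoxy on this same carbon would also leave the number undisturbed remains open, since methoxy is the only group shown there. The shared core outside this ring also stays constant across all the compounds shown, and a single-concentration read-out gives no potency, so how far these small differences extend to other parts of the molecule or to other concentrations is unknown.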